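Thiophene for chlorophenyl on the shared imidazopyrazine-free core description

The compounds below may be only part of what the source reports. "The series", "measured", "known", "first", "only" and "open" are said of these compounds alone.

Measured compounds:
compound 1 `c1ccc(-c2cn3ccnc3c(-c3ccc4ncn(C5CCCCC5)c4c3)n2)cc1`, 36.5%
compound 2 `Clc1ccc(-c2cn3ccnc3c(-c3ccc4ncn(C5CCCCC5)c4c3)n2)cc1`, 12.4%

In a functional assay on SK-MEL-5 cells (Homo sapiens) for inhibition, read by sulforhodamine B assay, with a stated time of 48 h, tested at 10 uM (on this read-out lower numbers stand for less inhibition and higher numbers for more inhibition at the one concentration tested (going by the name of the read-out)), compound 1 gives 36.5%, and compound 2 gives 12.4%, the lowest of the two numbers. Within the data shown here, the one step available, a number 24.1 percentage points lower from compound 1 to compound 2 (beyond the scatter), is the only comparison on record.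

Compound 3 `c1csc(-c2cn3ccnc3c(-c3ccc4ncn(C5CCCCC5)c4c3)n2)c1` is unmeasured. It differs from compound 2 by thiophen-2-yl in place of 4-chlorophenyl on an aromatic carbon. The measured step bears on this only in part: it shows what the chloro added to the phenyl ring did, whereas the change to compound 3 removes that chloro and replaces the whole six-membered ring by a five-membered one. Among the measured compounds shown here, no measured pair shows a thiophen-2-yl against a phenyl on this core, so the expectation leans on compound 1, whose value 36.5% is the reference without the chloro. Compound 3 is therefore expected to land between the two measured numbers, nearer compound 1, with an expected step of a number 15.6 percentage points higher from compound 2 to compound 3 (beyond the scatter). The estimate for compound 3 is 28%, within a range of 5% to 50%.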

Compound 3, a percentage reported as inhibition, at one concentration (the size of the read-out at that concentration, not a potency): 8.05%
Compound 3: middle estimate off by 20 percentage points, on the high side; the measured number falls inside the stated range.
By their numbers in this assay, from the lowest: compounds 3 and 2 (each within the scatter of the next); then compound 1.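

In this assay, thiophen-2-yl in place of 4-chlorophenyl on this aromatic carbon gives a number 4.4 percentage points lower from compound 2 to compound 3 (within the scatter), so the two groups cannot be told apart here. Set against the plain phenyl, the same five-membered ring gives a number 28.5 percentage points lower from compound 1 to compound 3 (beyond the scatter), which means that a second, structurally different replacement of phenyl at this position also falls short of compound 1, and compound 1 alone stands apart from the other two. No measurement at hand explains why the phenyl compound separates from the other two.

The compounds shown leave open whether any group on this carbon can rise above the phenyl of compound 1, or whether the phenyl marks a narrow optimum among aromatic rings. A pyridin-3-yl ring, or a phenyl ring bearing a methoxy group, an amine or a carboxylic acid, would show whether the drop seen with both the 4-chlorophenyl and the thiophen-2-yl compounds extends to other groups at this position.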